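The source may hold more compounds than are shown below. What is called first, only, known or untested is meant among the compounds shown, and "the series" means these compounds.

In a toxicity assay on MT4 cells (Homo sapiens) for cytotoxicity, read by MTT assay (a lower number here means that less compound is tolerated, a higher number that more compound is tolerated), compound 1 (`Cc1cc(-c2ccc(C#N)c(C#N)c2)ccc1Oc1cc(N)nc(Nc2ccc(C#N)cc2)n1`) gives 76700 nM, compound 2 (`Cc1cc(-c2ccc(F)cc2)ccc1Oc1cc(N)nc(Nc2ccc(C#N)cc2)n1`) gives 20100 nM, and compound 3 (`Cc1cc(-c2ccccc2C#N)ccc1Oc1cc(N)nc(Nc2ccc(C#N)cc2)n1`) gives 28600 nM. Compound 3 thus stands level with compound 2 within the scatter, and lower than compound 1. Compound 4 (`Cc1cc(-c2cccc(C#N)c2)ccc1Oc1cc(N)nc(Nc2ccc(C#N)cc2)n1`) carries 3-cyanophenyl in place of 2-cyanophenyl on an aromatic carbon. Going by the values given here, no measured step isolates this change. Exchanging the aryl group gave only a 1.4-fold higher number from compound 2 to compound 3 (0.15 log units; within the scatter), while the two modest steps, a 3.8-fold lower number from compound 1 to compound 2 (0.58 log units; beyond the scatter) and a 2.7-fold lower number from compound 1 to compound 3 (0.43 log units; beyond the scatter), both leave the 3,4-dicyanophenyl group, which compound 4 lacks. The expected change is therefore a 1.1-fold lower number from compound 3 to compound 4 (0.04 log units; within the scatter), with no step beyond the scatter. For compound 4 the estimated value is 26000 nM, with an expected range from 13000 nM to 55000 nM.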

Compound 4, half-maximal cytotoxic concentration: 27400 nM
Compound 4: middle estimate off by 1.1-fold (0.02 log units), on the low side; low and high end bracket the measured number.
By their numbers in this assay, from the lowest: compounds 2, 4 and 3 (each within the scatter of the next); then compound 1.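

In this assay, moving the nitrile from 2-cyanophenyl to 3-cyanophenyl leaves the number within the scatter (a 1.0-fold lower number from compound 3 to compound 4 (0.02 log units; within the scatter)), and 3-cyanophenyl in place of 4-fluorophenyl does the same (a 1.4-fold higher number from compound 2 to compound 4 (0.13 log units; within the scatter)). Hydrogen in place of one cyano of 3,4-dicyanophenyl is the only new step beyond the scatter (a 2.8-fold lower number from compound 1 to compound 4 (0.45 log units; beyond the scatter)), so the second nitrile, not the placing of a single one, separates compound 1 here. Nothing available explains these steps. From the compounds shown here alone, how 4-cyanophenyl compares remains open, as does how an amine or a carboxylic acid on this ring would compare.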